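This account rests on a few compounds, and the source may have more. Where it says the series, first, only, none or still open, it means among the compounds named here.

Three compounds share a core built from a benzimidazole-like bicycle joined to a phenyl ring that carries an amino group, and each has been tested in an ADME assay on MDBK cells (Bos taurus) for cytotoxicity, read by MTT assay, with a stated time of 96 h; on this read-out higher numbers stand for lower toxicity in this test and lower numbers for higher toxicity in this test. Compound 1 `CN1CCN(CC(=O)Nc2ccc(-c3nc4cc(Cl)c(Cl)cc4[nH]3)cc2)CC1` gives 90000 nM in this assay. Compound 2 `Nc1ccc(-c2nc3cc(Cl)c(Cl)cc3[nH]2)cc1`, which carries the amino group unsubstituted, gives 7500 nM in this assay. Compound 3 `O=C(O)CCC(=O)Nc1ccc(-c2nc3cc(C(F)(F)F)ccc3[nH]2)cc1` reaches only the upper limit of this assay, recorded as > 100000 nM, so for compound 3 no exact number is known, only that it lies at or beyond that limit; the limit of > 100000 nM in this assay, at which 1 of the 3 values shown sits, marks how it stands among the three values.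

Compound 4 `CCN(CC)CC(=O)Nc1ccc(-c2nc3cc(C(F)(F)F)ccc3[nH]2)cc1` has not yet been measured in this assay. It differs from compound 3 in one place: diethylamino in place of carboxymethyl on a saturated chain carbon bound to a carbonyl carbon. Among the measured compounds shown here, no step between two measured compounds matches this change, so the expectation must rest on the values themselves. Compound 1, which also carries an amino group on the chain, gives 90000 nM, and compound 2, with a free amino group, gives 7500 nM, so a value close to that of compound 1 and well above that of compound 2 seems plausible. For compound 4 the estimate is 70000 nM, within a range of 30000 nM to 150000 nM. This means an expected step of an at least 1.4-fold lower number from compound 3 to compound 4 (0.15 log units; that floor lies within the scatter), likely within the scatter or a modest fall.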

Compound 4, half-maximal cytotoxic concentration: 13000 nM
Compound 4: middle estimate off by 5.4-fold (0.73 log units), on the high side; measured number below the stated range.
By their numbers in this assay, from the lowest: compounds 2 and 4 (each within the scatter of the next); then compound 1. At a limit, above all of these: compound 3.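

In this assay, placing diethylamino in place of carboxymethyl on a saturated chain carbon bound to a carbonyl carbon gives an at least 7.6-fold lower number from compound 3 to compound 4 (0.88 log units; beyond the scatter), and this step lies beyond the usual scatter. Among the compounds shown here, it is the first comparison here between two measured compounds that differ in one place, and it shows that what sits at this position of the chain matters, with the change moving the read-out toward higher toxicity in this test. The size of the step is only a floor, and the real gap could be wider, as compound 3 stands at a limit of the assay and not at an exact number: the limit of > 100000 nM in this assay, at which 1 of the 4 values shown sits.

Going by these compounds, what stays open is whether the fall comes from losing the carboxylic acid, from gaining the amine, or from both, as this single change does the two things at once. A plain ethyl group at the same place, carrying neither an acid nor an amine, would help to separate the two, while a dimethylamino or morpholine group would show whether the result holds for other amines.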